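Isopropyl on the pendant ring of compound 1

The source may report more compounds than this note shows. Statements on the series, on what has been measured and on what is new or still open speak of the compounds shown alone.

Compound 1 `O=C1/C(=C/c2ccccc2)Cc2cc(O)ccc21` is one of three measured compounds that share one core and differ only on the pendant six-membered ring. In an assay on isolated protein for inhibition of Amine oxidase [flavin-containing] B (Homo sapiens), read by fluorescence and spectrophotometry, with a stated time of 20 min (a higher number here means a weaker inhibitor, a lower number a stronger inhibitor), compound 1 gives 376 nM, the second highest of the three numbers. Compound 2 `N#Cc1cccc(/C=C2\Cc3cc(O)ccc3C2=O)c1` gives 130 nM, and compound 3 `O=C1/C(=C/c2cccc(O)c2)Cc2cc(O)ccc21` gives 966 nM. The two measured steps from compound 1 pull in opposite directions: a 2.9-fold lower number from compound 1 to compound 2 (0.46 log units; beyond the scatter), whereas a 2.6-fold higher number from compound 1 to compound 3 (0.41 log units; beyond the scatter), and between the two substituted compounds a 7.4-fold higher number from compound 2 to compound 3 (0.87 log units; beyond the scatter).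

Compound 4 `CC(C)c1ccc(/C=C2\Cc3cc(O)ccc3C2=O)cc1` is not yet measured. It differs from compound 1 by isopropyl in place of hydrogen on an aromatic carbon. For the measured compounds named here, no measured step places a group at this spot, and no measured compound carries an isopropyl, so the two steps seen so far give only a rough scale: a single small group on this ring moved the number by a modest amount in either direction. Compound 4 is therefore expected to stay within a modest distance of compound 1, with a slight lean towards a lower number. The expected step is a 1.5-fold lower number from compound 1 to compound 4 (0.18 log units; within the scatter). The estimate for compound 4 in this assay is 250 nM, with a range from 70 nM to 900 nM.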

Compound 4, half-maximal inhibitory concentration: 215 nM
Compound 4: the middle estimate sits 1.2-fold (0.07 log units) above what was measured; the measured number falls inside the stated range.
By their numbers in this assay, from the lowest: compounds 2, 4 and 1 (each within the scatter of the next, the first and the last beyond it); then compound 3.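

The change read in this assay is a 1.7-fold lower number from compound 1 to compound 4 (0.24 log units; within the scatter) and so leaves compound 4 and compound 1 with numbers that cannot be told apart. For the compounds shown here, this is the first measured group on an aromatic carbon para to a large group, and the first single change on the pendant ring of compound 1 that stays within the scatter, whereas the cyano and hydroxy steps from compound 1 both went beyond it. No measurement shown here accounts for this result, so the reason for it remains unknown.

The compounds shown leave open whether an amine, a carboxylic acid or a longer chain such as butyl at this same spot would also stay close to compound 1, or would move the number beyond the scatter. They also leave open whether cyano or hydroxy placed at this spot would shift the number in the same directions as in compound 2 and compound 3, and whether isopropyl would behave the same way elsewhere on the ring.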